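The source may report more compounds than this note shows. Statements on the series, on what has been measured and on what is new or still open speak of the compounds shown alone.

In a functional assay on CCRF-CEM cells (Homo sapiens) for inhibition (on this read-out lower numbers stand for stronger inhibition and higher numbers for weaker inhibition), compound 1, whose structure is `Cc1cccc(/C=C2\Cc3ccccc3C2=O)c1`, gives 41300 nM. Compound 2, with the structure `COc1cccc(/C=C2\Cc3ccccc3C2=O)c1`, differs from compound 1 by a single change: methoxy in place of methyl on an aromatic carbon. In this assay compound 2 reaches only a limit of the assay, at > 500000 nM. Taken together these two values make the step of an at least 12-fold higher number from compound 1 to compound 2 (1.08 log units; beyond the scatter), a move toward much weaker inhibition; the size of that step rests on (the limit of > 500000 nM in this assay, at which 2 of the 3 values shown sit).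

Compound 3, with the structure `Cc1ccc(/C=C2\CCCCCC2=O)cc1`, is built on a different core; the difference between the two cores is not broken down here. In this assay compound 3 also gives only a limit of the assay, at > 500000 nM.

Compound 4, whose structure is `COc1ccc(/C=C2\CCCCCC2=O)cc1`, has not yet been measured. It differs from compound 3 in one place: methoxy in place of methyl on an aromatic carbon. For the measured compounds named here, this is the same kind of change as the one from compound 1 to compound 2, though not the same change: in compound 1 the group sits meta to a large group, while in compound 3 it sits para to a group of 9 heavy atoms.

With compound 3 already at a limit of the assay, and with the earlier step of an at least 12-fold higher number from compound 1 to compound 2 (1.08 log units; beyond the scatter) pointing toward weaker inhibition, compound 4 is expected to move by about a step that the limit leaves unreadable from compound 3 to compound 4. Compound 4 is therefore estimated to give roughly 800000 nM, within a range from 300000 nM to 3000000 nM, most likely reported again as a limit rather than a number.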

Compound 4, half-maximal inhibitory concentration: 194000 nM
Estimate against measurement, compound 4: 4.1-fold (0.62 log units) above, and the stated range ends above it.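

On the core of compound 3, methoxy in place of methyl gives an at least 2.5-fold lower number from compound 3 to compound 4 (0.41 log units; beyond the scatter), a move toward stronger inhibition and so the opposite direction to an at least 12-fold higher number from compound 1 to compound 2 (1.08 log units; beyond the scatter). The result of this change therefore cannot simply be carried from one core to the other in this assay, since the two steps differ clearly in direction: the same change on two cores in this assay, an at least 12-fold higher number (1.08 log units; beyond the scatter) from compound 1 to compound 2 and an at least 2.5-fold lower number (0.41 log units; beyond the scatter) from compound 3 to compound 4, at least 31-fold (1.49 log units) apart, beyond the scatter of two such steps This does not show how large either step truly is, and it does not separate the effect of the core from the effect of where the group sits, since the group also occupies a different place on its ring in the two pairs; the sizes are only lower bounds, as one value in each pair is a limit of the assay and not a number: the limit of > 500000 nM in this assay, at which 2 of the 4 values shown sit.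

The compounds shown leave open whether the reversal follows the core or the place on the ring, which a pair with methyl and methoxy at the same ring place on both cores could help settle. They also leave open how other groups at that place, such as chloro, hydroxyl or an amine, would behave on either core.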